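Substituent on the seven-membered ring: methoxy to phenyl

A few compounds are considered here, and "the series" means these few. Any claim that something is new, unique, unknown or untested is made for them only; others in the source may bear on it.

The series shares one core, carried by compound 1 `CCOC(=O)C(=O)Nc1cccccc1=O`, and is followed in a functional assay on the whole organism (strain Sprague-Dawley CD) for inhibition, with Rattus norvegicus as the target, read by paw edema, at a dose of 10 mg/kg by the intraperitoneal route; on this read-out lower numbers stand for a weaker effect and higher numbers for a stronger effect at the one dose given. Compound 1 gives 80%. Compound 2 `CCOC(=O)C(=O)Nc1ccccc(OC)c1=O` gives 24%, and compound 3 `CCOC(=O)C(=O)Nc1ccccc(N(C)C(=O)C(=O)OCC)c1=O` gives 26%. Compound 2 stands lowest of the three numbers; compound 3 is within the scatter of it, while compound 1 lies beyond the scatter above it. For the measured compounds named here, the only step between compounds differing in a single place is a number 56 percentage points lower from compound 1 to compound 2 (beyond the scatter), a large drop.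

Compound 4 `CCOC(=O)C(=O)Nc1ccccc(-c2ccccc2)c1=O` differs from compound 2 by phenyl in place of methoxy on an aromatic carbon. Going by the values given here, no measured step puts phenyl onto this aromatic carbon. The step from compound 1 to compound 2 bears on it only in that it shows the unsubstituted ring far stronger than the methoxy-bearing one, and compound 3 stays within the scatter of compound 2. Both substituted compounds thus sit low, and another substituent at this place is expected to leave compound 4 near that level, with no change beyond the scatter, so the expected step is a number 6 percentage points higher from compound 2 to compound 4 (within the scatter). Compound 4 is estimated at 30%, within 10% to 55%.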

Compound 4, a percentage reported as inhibition, in the whole organism at one dose (the size of the read-out at that dose, not a potency): 57%
The estimate for compound 4 lay 27 percentage points below the measured number, outside the stated range (above it).
By their numbers in this assay, from the lowest: compounds 2 and 3 (each within the scatter of the next); then compound 4; then compound 1.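

In this assay the aromatic carbon of the seven-membered ring does not respond to substitution as such, since the identity of the group matters: phenyl in place of methoxy gives a number 33 percentage points higher from compound 2 to compound 4 (beyond the scatter) and recovers a large part of the effect lost with methoxy. Phenyl in place of hydrogen still gives a number 23 percentage points lower from compound 1 to compound 4 (beyond the scatter) and so does not reach the level of the unsubstituted ring. Across the three compounds that differ only at this carbon, the order from the highest number is hydrogen in compound 1, phenyl in compound 4 and methoxy in compound 2, each step lying beyond the scatter, which the single earlier step could not show. No measured information on these compounds accounts for this order.

On these data alone, whether a chlorine atom, an amine, a carboxylic acid or a longer chain such as ethoxy on this carbon would fall nearer to phenyl or to methoxy remains open, as does the effect of a substituted phenyl. As far as these compounds go, all of these numbers are sizes of effect at one dose, so the order at other doses also remains open.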